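This account rests on a few compounds, and the source may have more. Where it says the series, first, only, none or still open, it means among the compounds named here.

In a functional assay on HepG2 cells (Homo sapiens) for antiproliferative activity, read by MTT assay, with a stated time of 24 h (a lower number here means a stronger inhibitor, a higher number a weaker inhibitor), compound 1 `COc1ccc(C(=O)/C=C/c2ccc([N+](=O)[O-])cc2)c2c1C=CC(C)(C)O2`, which carries 4-nitrophenyl, gives 2610 nM. Compound 2 `COc1ccc(/C=C/C(=O)c2ccc(OC)c3c2OC(C)(C)C=C3)cn1`, with 6-methoxypyridin-3-yl, reads > 10000 nM, which is a limit of the assay and not a number. Compound 3 `COc1ccc(C(=O)/C=C/c2ccccc2Cl)c2c1C=CC(C)(C)O2`, with 2-chlorophenyl, reads > 10000 nM, likewise a limit. Compound 3 therefore stands at the limit of > 10000 nM in this assay, at which 2 of the 3 values shown sit. Compound 4 `COc1ccccc1/C=C/C(=O)c1ccc(OC)c2c1OC(C)(C)C=C2` has methoxy in place of chloro on an aromatic carbon, ortho to a large group: methoxy in place of chloro on an aromatic carbon. Going by the values given here, no measured step makes this exact change. The nearest evidence is an at least 3.8-fold higher number from compound 1 to compound 3 (0.58 log units; beyond the scatter) and an at least 3.8-fold higher number from compound 1 to compound 2 (0.58 log units; beyond the scatter), while a step that the two limits leave unreadable from compound 2 to compound 3 gives no size. Only compound 1 gives a number, so a methoxy-bearing ring offers no sign of a gain here, given that compound 2 reads > 10000 nM in this assay. No clear step is therefore expected, and compound 4 will probably stay near the limit, in the same direction as compound 3, with an estimated a number no higher from compound 3 to compound 4 (the limit leaves the size open). For compound 4 the expected value in this assay is 10000 nM, with an estimated range of 3500 nM to 30000 nM.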

Compound 4, half-maximal inhibitory concentration: > 10000 nM
Compound 4 gave a limit, no number (the forecaster's own chance of this, stated with the estimate: 65%); the middle value sits exactly at the limit.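

In this assay compound 4 gives > 10000 nM, a limit of the assay and not a number, so on an aromatic carbon ortho to a large group neither chloro nor methoxy brings the compound into the readable range. The steps among compound 2, compound 3 and compound 4 cannot be read, so any difference between chloro and methoxy at this place stays hidden, while 2-methoxyphenyl in place of 4-nitrophenyl gives an at least 3.8-fold higher number from compound 1 to compound 4 (0.58 log units; beyond the scatter). Compound 1 is now the only compound with a number, and the others share one limit: the limit of > 10000 nM in this assay, at which 3 of the 4 values shown sit.

The compounds shown leave open whether an amine or a carboxylic acid in place of the nitro group would keep a readable value. They also leave open how far above the limit compound 2, compound 3 and compound 4 lie.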